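The source may report more compounds than this note shows. Statements on the series, on what has been measured and on what is new or still open speak of the compounds shown alone.

Measured in an ADME assay on HCT-116 cells (Homo sapiens) for cytotoxicity, read by CellTiter-Glo, with a stated time of 72 h; on this read-out lower numbers stand for stronger inhibition and higher numbers for weaker inhibition:
Compound 1 `CC1CCN(C2CCN(S(=O)(=O)c3ccc(C#N)cc3)CC2)CC1`: > 5000 nM (a limit)
Compound 2 `Cc1ccc(C2CCN(S(=O)(=O)c3c(C)cc(C)cc3C)CC2)cc1`: > 5000 nM (a limit)
Compound 3 `CC1CCN(C2CCN(S(=O)(=O)c3ccc(-c4ccccc4F)cc3)CC2)CC1`: > 5000 nM (a limit)

None of the three has a numerical value, and all sit at the same limit: the limit of > 5000 nM in this assay, at which 3 of the 3 values shown sit. Compound 1 therefore gives a limit and not a number as the starting point. Compound 4 `CC1CCN(C2CCN(S(=O)(=O)c3nccn3C)CC2)CC1` has not yet been measured. It carries 1-methyl-1H-imidazol-2-yl in place of 4-cyanophenyl on a sulfonyl sulfur.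

Going by the values given here, only one measured step starts from compound 1, and it changes a different place, an aromatic carbon. That step is a step that the two limits leave unreadable from compound 1 to compound 3, so it offers no size to carry over. With no readable step in either direction, no change beyond the scatter is expected in this assay. The expected step is a step that the limit leaves unreadable from compound 1 to compound 4. Another report at the limit is considered likely. For compound 4 the estimated value is 7000 nM, with an expected range from 3000 nM to 20000 nM.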

Compound 4, half-maximal inhibitory concentration: > 10000 nM
Compound 4: a limit, no number; the forecaster's own chance of this, stated with the estimate: 90%; middle value at least 1.4-fold (0.15 log units) from the limit.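

Going by these compounds alone, compound 1 and compound 4 each give only a limit in this assay, and no step between the two can be read. The compounds shown leave open whether 1-methyl-1H-imidazol-2-yl in place of 4-cyanophenyl changes the read-out at all, as none of the four has a numerical value.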